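From Methyl to Thiophen-2-yl: A Small Step Expected

The source may report more compounds than this note shows. Statements on the series, on what has been measured and on what is new or still open speak of the compounds shown alone.

In a functional assay on HCT-116 cells (Homo sapiens) for cytotoxicity, read by MTT assay, with a stated time of 72 h (a higher number here means a weaker inhibitor, a lower number a stronger inhibitor), compound 1 `CC[S+]([O-])CCCCN=C=S` gives 3850 nM. In the same test, compound 2 `O=[N+]([O-])c1ccc(C[S+]([O-])CCCCN=C=S)cc1` gives 2830 nM. Within the data shown here, these are the only two numbers so far, and they lie within the scatter of repeated measurements, so they cannot be told apart and neither compound can be ranked over the other.

Still unmeasured is compound 3 `[O-][S+](CCCCN=C=S)Cc1cccs1`, which differs from compound 1 in one place: thiophen-2-yl in place of methyl on a saturated chain carbon bound to a sulfur. Put simply, thiophen-2-yl stands in place of methyl on a saturated chain carbon bound to a sulfur. Among the measured compounds shown here, no measured pair yet shows what this swap does, so any forecast rests on very little. Compound 1 at 3850 nM and compound 2 at 2830 nM sit close together, so no step beyond the scatter is expected in this assay. A larger move in either direction cannot be ruled out. For compound 3, the estimated value is 3000 nM, with an expected range from 1300 nM to 7000 nM. This estimate means an expected step of a 1.3-fold lower number from compound 1 to compound 3 (0.11 log units; within the scatter).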

Compound 3, half-maximal inhibitory concentration: 3210 nM
Compound 3: the middle estimate sits 1.1-fold (0.03 log units) below what was measured; measured number inside the range.
By their numbers in this assay, from the lowest: compounds 2, 3 and 1 (each within the scatter of the next).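

In this assay, among these compounds, the swap of methyl for thiophen-2-yl on a saturated chain carbon bound to a sulfur gives a 1.2-fold lower number from compound 1 to compound 3 (0.08 log units; within the scatter), and this is the first measured pair in which only one place differs. It shows that, in this test, this position can carry one five-membered aromatic ring with a hydrogen-bond acceptor instead of a single carbon with no ring, and the step still stays within the scatter, so the swap shows no measurable effect on the number read here. No measurement at hand offers an explanation for how close the two numbers lie.

This single pair cannot show how far that holds for other kinds of group at the same position: an amine or a carboxylic acid in place of methyl could give a step of any size in this test. As far as these compounds go, a longer chain of plain carbons in place of methyl is equally open, and so is whether any group on this carbon can move the number beyond the scatter at all.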